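A trifluoromethyl swap on a short-lived compound

The compounds below may be only part of what the source reports. "The series", "measured", "known", "first", "only" and "open" are said of these compounds alone.

Measured in an ADME assay on microsomes from liver (Homo sapiens) for metabolic stability; on this read-out lower numbers stand for a shorter-lived compound and higher numbers for a longer-lived compound:
Compound 1 `CC#C[C@@H](Cc1nnn[nH]1)c1ccc(OCc2ccc3scc(-c4cccnc4C)c3c2)cc1`: < 0.0667 h
Compound 2 `CC#C[C@@H](Cc1nnn[nH]1)c1ccc(OCc2ccc3sc(I)c(-c4ccccc4C)c3c2)cc1`: 0.167 h

Compound 1 has no exact half-life, and all that is known of compound 1 is the limit of < 0.0667 h in this assay, at which 1 of the 2 values shown sits. This is a limit of the assay and not a number. Compound 2 gives a true number, 0.167 h.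

The next compound to be tested is compound 3 `CC#C[C@@H](Cc1nnn[nH]1)c1ccc(OCc2ccc3scc(-c4ccccc4C(F)(F)F)c3c2)cc1`. It keeps the core of compound 1 but carries 2-(trifluoromethyl)phenyl in place of 2-methylpyridin-3-yl on an aromatic carbon. Going by the values given here, no two measured compounds differ in one place only, which means the effect of this change has not been seen directly in this assay.

Among the compounds with values here, the only numerical guide is compound 2 at 0.167 h, and compound 3 is expected to land near that value, with a modest move towards a longer half-life. The expected change is an at least 1.9-fold higher number from compound 1 to compound 3 (0.28 log units; that floor lies within the scatter), and it could prove small. For compound 3 the estimated half-life is 0.13 h, with an expected range from 0.06 h to 0.35 h.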

Compound 3, half-life: < 0.0667 h
Compound 3: a limit, no number; the forecaster's own chance of this, stated with the estimate: 30%; at least 1.9-fold (0.28 log units) between middle value and limit.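

Going by these compounds alone, compound 3, like compound 1, stops at a limit of the assay and not a number, so no step from compound 1 to compound 3 can be read: the limit of < 0.0667 h in this assay, at which 2 of the 3 values shown sit.

Going by these compounds, what stays open is how long compound 1 and compound 3 actually last, and so whether 2-(trifluoromethyl)phenyl in place of 2-methylpyridin-3-yl on an aromatic carbon changes the half-life at all.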